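The source may hold more compounds than are shown below. What is called first, only, known or untested is meant among the compounds shown, and "the series" means these compounds.

Compound 1 `CC(C)NC(=O)CCC(NS(=O)(=O)c1cc(Cl)ccc1Cl)C(=O)NC(C)C` and compound 3 `Cc1ccc(Cl)c(S(=O)(=O)NC(CCC(=O)NC(C)C)C(=O)NC(C)C)c1` share a core, while compound 2 `CCCCNC(=O)CCC(NS(=O)(=O)c1cc(Cl)ccc1Cl)C(=O)NCCCC` carries another; the difference between the two cores is not broken down here. In a functional assay on IMR-32 cells (Homo sapiens) for cytotoxicity, read by MTT assay, tested at 60 ug/mL (on this read-out lower numbers stand for less inhibition and higher numbers for more inhibition at the one concentration tested (going by the name of the read-out)), compound 1 gives 16.7%, compound 3 gives 29.8%, and compound 2 gives 15.8%. The change from compound 1 to compound 3, (methyl in place of chloro on an aromatic carbon), made a step of a number 13.1 percentage points higher from compound 1 to compound 3 (beyond the scatter). Compound 4 `CCCCNC(=O)CCC(NS(=O)(=O)c1cc(C)ccc1Cl)C(=O)NCCCC` arises from compound 2 by the same change, (methyl in place of chloro on an aromatic carbon). Because the earlier step was a number 13.1 percentage points higher from compound 1 to compound 3 (beyond the scatter), a step of about a number 12.2 percentage points higher from compound 2 to compound 4 (beyond the scatter) is expected in this assay for compound 4, though this rests on a single pair and the two cores are not the same. Compound 4 is therefore estimated at 28%, with a likely range from 17% to 40%.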

Compound 4, a percentage reported as inhibition, at one concentration (the size of the read-out at that concentration, not a potency): 18%
Compound 4: the middle estimate sits 10 percentage points above what was measured; the measured number falls inside the stated range.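

In this assay, among these compounds, methyl in place of chloro gave a number 2.2 percentage points higher from compound 2 to compound 4 (within the scatter), so on the core of compound 2 the change produced no step that stands clear of the scatter. Set beside the earlier step, this one does not differ from it by more than two such steps can scatter: the same change on two cores in this assay, a number 13.1 percentage points higher (beyond the scatter) from compound 1 to compound 3 and a number 2.2 percentage points higher (within the scatter) from compound 2 to compound 4, 10.9 percentage points apart, within the scatter of two such steps The two steps therefore neither show that the change carries from one core to the other at the same size nor show that it fails to carry, and two pairs cannot settle the question.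

From the compounds shown here alone, what a fluoro or methoxy group would do on that aromatic carbon remains open. So does the effect of a longer chain on the two amides.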